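The source may report more compounds than this note shows. Statements on the series, on what has been measured and on what is new or still open speak of the compounds shown alone.

Compound 3 `CC(C)(C)c1ccc(C(=O)N2CCC3(CC2)C(=O)N(CC(=O)NCCCCO)CN3c2ccccc2)cc1` stands at the weak end of this small series: in an assay on HEK293 cells for displacement of a labelled ligand from NPC1-like intracellular cholesterol transporter 1 (Homo sapiens) (on this read-out lower numbers stand for stronger inhibition and higher numbers for weaker inhibition), compound 3 gives 19200 nM, the highest of the three numbers recorded. The two neighbours sit close to each other. In this assay compound 1 `CC(C)(C)OC(=O)NCCCNC(=O)CN1CN(c2ccccc2)C2(CCN(C(=O)c3ccc(C(C)(C)C)cc3)CC2)C1=O` gives 4500 nM, and compound 2 `CC(C)(C)c1ccc(C(=O)N2CCC3(CC2)C(=O)N(CC(=O)NCCCN)CN3c2ccccc2)cc1` gives 4200 nM; the step of a 1.1-fold lower number from compound 1 to compound 2 (0.03 log units; within the scatter) is within the scatter. By contrast a 4.3-fold higher number from compound 1 to compound 3 (0.63 log units; beyond the scatter) and a 4.6-fold higher number from compound 2 to compound 3 (0.66 log units; beyond the scatter) are both beyond the scatter, so exchanging the amine-bearing chain end for a hydroxyl-bearing one costs potency in a modest way.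

Compound 4 `CCOC(=O)C1CCCN(C(=O)CN2CN(c3ccccc3)C3(CCN(C(=O)c4ccc(C(C)(C)C)cc4)CC3)C2=O)C1` is reached from compound 3 by 3-(ethoxycarbonyl)piperidin-1-yl in place of (4-hydroxybutyl)amino on a carbonyl carbon. Among the measured compounds shown here, no measured step covers this exchange: the chain amide is replaced outright rather than altered at its end, and the ring ester has no counterpart among the measured compounds. For the measured compounds named here, the only guidance is that the hydroxybutyl chain of compound 3 gave the weakest number, so removing it leaves room for movement in either direction, with a mild lean toward recovery. Compound 4 is therefore expected to show a step of a 2.1-fold lower number from compound 3 to compound 4 (0.33 log units; beyond the scatter) in this assay, and its number is estimated at 9000 nM, within a range of 2500 nM to 35000 nM.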

Compound 4, half-maximal inhibitory concentration: 8200 nM
Beside the measured number, compound 4's estimate is 1.1-fold (0.04 log units) above it, and the stated range covers the measured number.
By their numbers in this assay, from the lowest: compounds 2, 1 and 4 (each within the scatter of the next); then compound 3.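

In this assay the exchange on the carbonyl carbon gives a 2.3-fold lower number from compound 3 to compound 4 (0.37 log units; beyond the scatter) and so shows that this place accepts more than an open chain: 3-(ethoxycarbonyl)piperidin-1-yl, with its six-membered non-aromatic ring, 11 heavy atoms and 0 hydrogen-bond donors, recovers part of what the (4-hydroxybutyl)amino chain had lost. Set against the other two chains, the same group gives a 2.0-fold higher number from compound 2 to compound 4 (0.29 log units; within the scatter) and a 1.8-fold higher number from compound 1 to compound 4 (0.26 log units; within the scatter) with both steps within the scatter, so neither the amide hydrogen nor the amine or protected amine at the chain end is required for inhibition in this range. The data offer no evidence on why the numbers at this place fall as they do.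

The compounds shown leave open whether the ring alone accounts for the result or the ester takes part, which a plain piperidin-1-yl group or the free carboxylic acid in place of the ethoxycarbonyl would separate. Also open, going by these compounds, is whether the ester's place on the ring counts, which 4-(ethoxycarbonyl)piperidin-1-yl would test.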